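A Cyclopropyl Swap on the Amide Nitrogen, Seen Twice

The source may report more compounds than this note shows. Statements on the series, on what has been measured and on what is new or still open speak of the compounds shown alone.

Measured compounds:
compound 1, `O=C(/C=C1\CCc2cc(F)cc(F)c21)NC1CC1`: 81 mg/kg
compound 2, `NC(=O)/C=C1\CCc2c(F)cc(F)cc21`: 138 mg/kg
compound 3, `NC(=O)/C=C1\CCc2cc(F)cc(F)c21`: 81 mg/kg

All three compounds were tested in a functional assay on the whole organism with Mus musculus as the target, in the rotarod test; a higher number here means that more compound is needed for the effect, a lower number that less compound is needed. Compound 1 and compound 3 differ in a single place: cyclopropyl in place of hydrogen on an amide-type nitrogen. This change made the step of no change at the digits printed from compound 3 to compound 1 (within the scatter). Compound 2 is built from the same atoms as compound 3, joined differently, so the two are best seen as two cores; the difference between the two cores is not broken down here. In this assay compound 2 gives 138 mg/kg, the highest of the three numbers, but its gaps to compound 1 and to compound 3 both lie within the scatter, so no order between them can be read from these data.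

Compound 4, `O=C(/C=C1\CCc2c(F)cc(F)cc21)NC1CC1`, has not been measured. It stands to compound 2 as compound 1 stands to compound 3: cyclopropyl in place of hydrogen on an amide-type nitrogen. The place is described in the same words for both pairs, so this is the same change, now carried out on the core of compound 2. For the measured compounds named here, the one measured instance left the number where it was, so the step from compound 2 to compound 4 is expected to be about a 1.1-fold lower number from compound 2 to compound 4 (0.03 log units; within the scatter), because no change at the digits printed from compound 3 to compound 1 (within the scatter) showed no shift. On this basis compound 4 is expected to give about 130 mg/kg. Since this rests on a single earlier instance, the expected range for compound 4 runs from 65 mg/kg to 270 mg/kg.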

Compound 4, dose for half-maximal effect: 62 mg/kg
The estimate for compound 4 lay 2.1-fold (0.32 log units) above the measured number; the whole stated range lies above it.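

Putting cyclopropyl in place of the amide hydrogen on the core of compound 2 gave, in this assay, a 2.2-fold lower number from compound 2 to compound 4 (0.35 log units; beyond the scatter), so on this core less compound was needed for the effect once the cyclopropyl was present. Setting this step beside the same change on the core of compound 3 gives the main comparison, and the two steps cannot be told apart: the same change on two cores in this assay, no change at the digits printed (within the scatter) from compound 3 to compound 1 and a 2.2-fold lower number (0.35 log units; beyond the scatter) from compound 2 to compound 4, 2.2-fold (0.35 log units) apart, within the scatter of two such steps. For the compounds shown here, although only one of the two steps lies beyond the scatter when taken alone, this does not show that the change behaves differently on the two cores, nor does it prove that it behaves identically, since two pairs in a single assay are too few to settle either reading.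

The compounds shown leave open whether other groups on the same nitrogen, such as a methyl group, a longer chain like n-butyl or a larger ring like cyclohexyl, would give steps of similar size on both cores. They also leave open what would happen if the amide itself gave way to another group, such as a carboxylic acid, on either core.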